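This account rests on a few compounds, and the source may have more. Where it says the series, first, only, none or still open, it means among the compounds named here.

Working notes on the series around compound 1 `O=C(c1ccc2c(c1)OCCO2)C1CCN(Cc2coc(-c3ccc(C(F)(F)F)cc3)n2)CC1` in an ADME assay on HEK293 cells (Homo sapiens) for cytotoxicity, read by MTT assay, with a stated time of 36 h; a lower number here means a stronger inhibitor, a higher number a weaker inhibitor. In this assay compound 1 gives > 150 ug/mL, which is a limit of the assay and not a number. Compound 2 `O=C(c1ccc2c(c1)OCCO2)C1CCN(Cc2coc(-c3ccc(F)c(F)c3)n2)CC1` gives > 150 ug/mL, also a limit. Compound 3 `COc1ccc(-c2nc(CN3CCC(C(=O)c4ccc5c(c4)OCCO5)CC3)co2)cc1` gives > 150 ug/mL, again a limit. All three values sit at the limit of > 150 ug/mL in this assay, at which 3 of the 3 values shown sit, so the steps a step that the two limits leave unreadable from compound 1 to compound 2, a step that the two limits leave unreadable from compound 1 to compound 3 and a step that the two limits leave unreadable from compound 2 to compound 3 cannot be read in size or direction. Compound 4 `CC(C)(C)c1ccc(-c2nc(CN3CCC(C(=O)c4ccc5c(c4)OCCO5)CC3)co2)cc1` is not yet measured; it differs from compound 1 by tert-butyl in place of trifluoromethyl on an aromatic carbon. Within the data shown here, no measured step bears directly on this change, and the measured ones are unreadable, so the expected step has no anchor in a readable number. Compound 4 is therefore expected to give 150 ug/mL (range 100 ug/mL to 300 ug/mL), most likely as a limit once more. The step estimated in this assay is a number no higher from compound 1 to compound 4 (the limit leaves the size open).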

Compound 4, half-maximal inhibitory concentration: > 150 ug/mL
Compound 4: no number, only a limit; the forecaster's own chance of this, stated with the estimate: 85%; the middle value lies on the limit itself.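

No step between compound 4 and compound 1, compound 2 or compound 3 can be read, since each value is a limit and not a number: the limit of > 150 ug/mL in this assay, at which 4 of the 4 values shown sit.

The compounds shown leave open where any of the four would reach half-maximal inhibition in this assay, and so whether the changes among them differ at all.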